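Trifluoromethoxy in place of fluoro on the biaryl diol

The source may hold more compounds than are shown below. What is called first, only, known or untested is meant among the compounds shown, and "the series" means these compounds.

Compound 1 `OCCCCCC(O)c1ccc(-c2ccc(F)cc2)cc1` gives 18000 nM in a functional assay on J774 cells (Mus musculus) for cytotoxicity, read by resazurin assay (a lower number here means a stronger inhibitor, a higher number a weaker inhibitor), the highest of the two numbers shown there. Compound 2 `OCCCCCC(O)c1ccc(-c2ccc(F)cc2F)cc1` gives 8000 nM in this assay, with a 2.3-fold lower number from compound 1 to compound 2 (0.35 log units; beyond the scatter). Compound 3 `Cc1cccc(-c2ccc(C(O)CCCCCO)cc2)c1` reaches only a limit of this assay, > 100000 nM. Compound 4 `OCCCCCC(O)c1ccc(-c2ccc(OC(F)(F)F)cc2)cc1` differs from compound 1 in one place: trifluoromethoxy in place of fluoro on an aromatic carbon. Among the compounds with values here, two measured steps bear on this change: adding a fluorine gave the modest 2.3-fold lower number from compound 1 to compound 2 (0.35 log units; beyond the scatter), whereas replacing the fluorinated ring gave an at least 5.5-fold higher number from compound 1 to compound 3 (0.74 log units; beyond the scatter), resting on (the limit of > 100000 nM in this assay, at which 1 of the 3 values shown sits). Neither step matches the present change closely, so compound 4 is expected to show at most a small shift, a 1.5-fold lower number from compound 1 to compound 4 (0.18 log units; within the scatter). Compound 4 is therefore estimated at 12000 nM, within a range from 4000 nM to 40000 nM.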

Compound 4, half-maximal inhibitory concentration: 14000 nM
For compound 4 the middle estimate is 1.2-fold (0.07 log units) below the measured one; the range from low to high includes it.
By their numbers in this assay, from the lowest: compounds 2, 4 and 1 (each within the scatter of the next, the first and the last beyond it). At a limit, above all of these: compound 3.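

Putting trifluoromethoxy, with five heavy atoms and one hydrogen-bond acceptor, where fluoro had one heavy atom and none gives a 1.3-fold lower number from compound 1 to compound 4 (0.11 log units; within the scatter) in this assay. Within the data shown here, this position, para to a large group, therefore takes a much bulkier substituent with no shift beyond the scatter, which the earlier compounds did not show. Nothing measured here gives a reason for this result.

As far as these compounds go, whether an amine or a carboxylic acid on this same carbon would leave the number as little moved remains open. So does the effect of a longer chain there.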